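This account rests on a few compounds, and the source may have more. Where it says the series, first, only, none or still open, it means among the compounds named here.

Measured in a physicochemical assay for metabolic stability, read by HPLC and mass spectrometry, in phosphate buffer, at 37 degrees C, at pH 7.4; a lower number here means that the compound disappears faster, a higher number that the compound lasts longer:
- compound 1 `CC(C)(O/N=C(\C(=O)N[C@@H]1C(=O)N(S(=O)(=O)O)[C@@H]1CN1CCC1=O)c1csc(N)n1)C(=O)O`: > 1000 h (a limit, not a number)
- compound 2 `CC(C)(O/N=C(\C(=O)N[C@@H]1C(=O)N(S(=O)(=O)O)[C@@H]1Cn1cncn1)c1csc(N)n1)C(=O)O`: 233 h

Within the data shown here, compound 2 holds the only true number, so it has no measured neighbour to be ranked against: the limit of > 1000 h in this assay, at which 1 of the 2 values shown sits.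

Compound 3 `CC(C)(O/N=C(\C(=O)N[C@@H]1C(=O)N(S(=O)(=O)O)[C@@H]1CN1C[C@@H](CN)OC1=O)c1csc(N)n1)C(=O)O` is the next to be read. The structural change is a group of 8 heavy atoms (4 carbon, 2 nitrogen, 2 oxygen; one five-membered non-aromatic ring with 2 hetero atoms) in place of a group of 5 heavy atoms (2 carbon, 3 nitrogen; one five-membered aromatic ring with 3 hetero atoms), on a saturated chain carbon bound to a saturated ring carbon.

Among the measured compounds shown here, one measured step bears on this, at the same place on the chain: an at least 4.2-fold lower number from compound 1 to compound 2 (0.63 log units; beyond the scatter). There, 1H-1,2,4-triazol-1-yl replaced 2-oxoazetidin-1-yl, so the aromatic ring came with the lower number. Compound 3 gives up that aromatic ring for a non-aromatic one, so a modest rise in this assay is expected, resting on this single open-ended step.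

The expected change is a 2.1-fold higher number from compound 2 to compound 3 (0.33 log units; beyond the scatter).

The estimated half-life of compound 3 is 500 h, with an expected range from 150 h to 1500 h.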

Compound 3, half-life: > 37 h
Compound 3: a limit, no number; the forecaster's own chance of this, stated with the estimate: 20%; the middle value is on the limit's open side.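

In this assay compound 3 gives > 37 h, a limit and not a number. The steps from compound 2 and from compound 1 to compound 3 cannot be read. The compounds shown leave open how compound 3 ranks against either compound.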